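A few compounds are considered here, and "the series" means these few. Any claim that something is new, unique, unknown or untested is made for them only; others in the source may bear on it.

Of the compounds shown here, three of this set have been measured in an assay on microsomes from intestine for inhibition of acyl-CoA:cholesterol acyltransferase (Oryctolagus cuniculus); on this read-out lower numbers stand for stronger inhibition and higher numbers for weaker inhibition. Compound 1 `Cc1cccc(C)c1NC(=O)CC(=O)Oc1c(C(C)C)cccc1C(C)C` gives 210 nM. Compound 2 `CCCCCCCCCCOC(=O)CC(=O)Nc1c(C(C)C)cccc1C(C)C` gives 53 nM, and compound 3 `CCCCCCOC(=O)CC(=O)Nc1c(C(C)C)cccc1C(C)C` gives 810 nM. Among these three numbers, compound 1 stands second highest: compound 3 is nearest to it and compound 2 furthest, and both gaps are beyond the scatter. Within the data shown here, the single change in one place among the measured compounds is a 15-fold higher number from compound 2 to compound 3 (1.18 log units; beyond the scatter), a change on the saturated chain and not on either aromatic ring.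

Compound 4 `CC(C)c1cccc(C(C)C)c1OC(=O)CC(=O)Nc1c(F)cccc1F` differs from compound 1 at another place altogether: 2,6-difluorophenyl in place of 2,6-dimethylphenyl on an amide-type nitrogen, on an amide-type nitrogen whose other neighbours are a carbonyl carbon. Among the measured compounds shown here, no measured pair shows this exchange, nor any change on that ring, so the step from compound 2 to compound 3 tells nothing about it. For the measured compounds named here, with no measured step pointing in either direction, the number for compound 4 is expected to sit close to that of compound 1. The expected step is a 1.2-fold higher number from compound 1 to compound 4 (0.08 log units; within the scatter), which lies within the scatter. Compound 4 is therefore estimated at 250 nM, within a range from 70 nM to 900 nM.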

Compound 4, half-maximal inhibitory concentration: 6200 nM
Compound 4: middle estimate off by 25-fold (1.39 log units), on the low side; the whole stated range lies below it.
By their numbers in this assay, from the lowest: compound 2; then compound 1; then compound 3; then compound 4.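

The ring on the amide-type nitrogen proves to be far from neutral: in this assay, the exchange of 2,6-dimethylphenyl for 2,6-difluorophenyl gives a 30-fold higher number from compound 1 to compound 4 (1.47 log units; beyond the scatter) and so weakens inhibition, which shows that this position, like the saturated chain with its a 15-fold higher number from compound 2 to compound 3 (1.18 log units; beyond the scatter), can shift the number by a large amount. The two groups match in everything counted for them, with the same number of heavy atoms, the same six-membered aromatic ring of carbon only, no hydrogen-bond donors or acceptors and no net charge, so those counts do not separate them, and the visible difference is fluorine in place of methyl. Nothing available here gives a reason for the loss.

As far as these compounds go, it remains open whether the drop belongs to fluorine in particular or to the loss of the methyl groups, which a 2,6-dichlorophenyl group or a plain phenyl group at the same place could help to separate. From the compounds shown here alone, it is also open whether the same exchange would have a similar effect in compound 2 or compound 3, which carry a saturated chain instead of a second aromatic ring.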